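The source may report more compounds than this note shows. Statements on the series, on what has been measured and on what is new or still open speak of the compounds shown alone.

Compound 3 `Cc1nn([C@H](C)c2ccc(Cl)cc2Cl)c2nc(N3CC[C@H](N4CCC[C@H]4CCC#N)[C@H](C)C3)cnc12` gives 41 nM in a functional assay on cells for antagonist activity at C-C chemokine receptor type 4 (Homo sapiens), read by fluorescence and calcium flux, with stated times of 2.5 s and 45 s; a higher number here means a weaker inhibitor, a lower number a stronger inhibitor; compound 2 `Cc1nn([C@H](C)c2ccc(Cl)cc2Cl)c2nc(N3CC[C@H](N4CCC[C@H]4CCC(N)=O)[C@H](C)C3)cnc12` gives 37 nM and compound 1 `Cc1nn([C@H](C)c2ccc(Cl)cc2Cl)c2nc(N3CC[C@H](N4CCCC4)[C@H](C)C3)cnc12` gives 69 nM. Compound 3 stands inside the scatter of both neighbours: a 1.1-fold higher number from compound 2 to compound 3 (0.04 log units; within the scatter) and a 1.7-fold lower number from compound 1 to compound 3 (0.23 log units; within the scatter). Compound 4 `Cc1nn([C@H](C)c2ccc(Cl)cc2Cl)c2nc(N3CC[C@H](N4CCC[C@H]4CO)[C@H](C)C3)cnc12` differs from compound 3 by hydroxy in place of cyanomethyl on a saturated chain carbon bound to a saturated ring carbon. Going by the values given here, the steps that bear on this change are those that alter the substituent on the saturated ring carbon: a 1.9-fold lower number from compound 1 to compound 2 (0.27 log units; within the scatter), a 1.7-fold lower number from compound 1 to compound 3 (0.23 log units; within the scatter) and a 1.1-fold higher number from compound 2 to compound 3 (0.04 log units; within the scatter), none beyond the scatter. Nothing in these three compounds separates the hydroxymethyl group from the groups already tried, so no step beyond the scatter is expected in this assay; the expected step is a 1.1-fold higher number from compound 3 to compound 4 (0.04 log units; within the scatter). Compound 4 is therefore estimated at 45 nM, with a range from 20 nM to 100 nM.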

Compound 4, half-maximal inhibitory concentration: 32 nM
Estimate against measurement, compound 4: 1.4-fold (0.15 log units) above; the measured number falls inside the stated range.
By their numbers in this assay, from the lowest: compounds 4, 2, 3 and 1 (each within the scatter of the next, the first and the last beyond it).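

In this assay, going by these compounds alone, hydroxymethyl in place of hydrogen on the saturated ring carbon gives the only step at this position printed as beyond the scatter, and a modest one (a 2.2-fold lower number from compound 1 to compound 4 (0.33 log units; beyond the scatter)). Hydroxy in place of cyanomethyl (a 1.3-fold lower number from compound 3 to compound 4 (0.11 log units; within the scatter)) or carbamoylmethyl (a 1.2-fold lower number from compound 2 to compound 4 (0.06 log units; within the scatter)) stays within the scatter, so compounds 2, 3 and 4 are not separated from one another. From the compounds shown here alone, whether an amine or a carboxylic acid on this chain, or a longer chain ending in hydroxy, would leave that scatter stays open. No supporting data explain these numbers.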